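Chloro for trifluoromethyl on the phenylsulfonyl ring

The compounds below may be only part of what the source reports. "The series", "measured", "known", "first", "only" and "open" are said of these compounds alone.

Measured in a functional assay on HepG2 cells (Homo sapiens) for cytotoxicity, read by MTT assay, with a stated time of 24 h (a higher number here means a weaker inhibitor, a lower number a stronger inhibitor), so far:
Compound 1 `O=C1/C(=C/c2ccncc2)CNC/C1=C\c1ccccc1C(F)(F)F` gives 6130 nM
Compound 2 `O=C1/C(=C/c2ccncc2)CN(S(=O)(=O)c2ccccc2)C/C1=C\c1ccccc1C(F)(F)F` gives 7020 nM
Compound 3 `O=C1/C(=C/c2ccncc2)CN(S(=O)(=O)c2ccc(C(F)(F)F)cc2)C/C1=C\c1ccccc1C(F)(F)F` gives 3240 nM

Compound 3 is separated only from compound 2 and stays within the scatter of compound 1. Next in the series is compound 4 `O=C1/C(=C/c2ccncc2)CN(S(=O)(=O)c2ccc(Cl)cc2)C/C1=C\c1ccccc1C(F)(F)F` with chloro in place of trifluoromethyl on an aromatic carbon, the change being chloro in place of trifluoromethyl on an aromatic carbon and the cut one bond further out reading 4-(trifluoromethyl)phenyl to 4-chlorophenyl.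

For the measured compounds named here, two measured steps bear on this. The step of a 1.1-fold higher number from compound 1 to compound 2 (0.06 log units; within the scatter) adds the unsubstituted phenylsulfonyl group and stays within the scatter. The step of a 2.2-fold lower number from compound 2 to compound 3 (0.34 log units; beyond the scatter) is the only one at the carbon now in question, and it is modest, only just beyond the scatter. Going by the values given here, no chloro compound has a measured value yet, so the reach of the new group is unknown. With so small a step at this carbon, only a small change is expected in this assay and the number may drift slightly upward towards compound 2 at 7020 nM without leaving the scatter. The expected step is a 1.2-fold higher number from compound 3 to compound 4 (0.07 log units; within the scatter) and no larger shift is anticipated. Compound 4 is estimated at 3800 nM with a range of 2000 nM to 7000 nM as expected bounds.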

Compound 4, half-maximal inhibitory concentration: 7190 nM
Compound 4: middle estimate off by 1.9-fold (0.28 log units), on the low side; measured number outside the range, above it.
By their numbers in this assay, from the lowest: compounds 3, 1, 2 and 4 (each within the scatter of the next, the first and the last beyond it).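

In this assay, chloro in place of trifluoromethyl on this aromatic carbon, para to a large group, gives a 2.2-fold higher number from compound 3 to compound 4 (0.35 log units; beyond the scatter), so the modest separation seen at this carbon does not carry over from trifluoromethyl to chloro. Chloro in place of hydrogen at the same carbon gives a 1.0-fold higher number from compound 2 to compound 4 (0.01 log units; within the scatter), and (4-chlorophenyl)sulfonyl in place of hydrogen on the amine nitrogen in a ring gives a 1.2-fold higher number from compound 1 to compound 4 (0.07 log units; within the scatter); among hydrogen, chloro and trifluoromethyl at this carbon, only trifluoromethyl stands apart from the other two. No available measurement offers an explanation for this difference between chloro and trifluoromethyl.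

Still open, going by these compounds, is whether the separation is confined to trifluoromethyl or also appears with other groups at this carbon, such as a nitrile, a methoxy group or an amine. Also open, on these data alone, is whether the trifluoromethyl step persists when an amide carbonyl replaces the sulfonyl link on the amine nitrogen in a ring.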